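Swapping a fluoro-methoxyphenyl pendant for a chlorophenyl one

The compounds below may be only part of what the source reports. "The series", "measured", "known", "first", "only" and "open" are said of these compounds alone.

Compound 1 `COc1cc(-n2cnc3ccc(-c4cccc(N)c4)cc32)cc(OC)c1OC` gives 640 nM in a functional assay on A549 cells (Homo sapiens) for antiproliferative activity, read by MTT assay, with a stated time of 72 h; a higher number here means a weaker inhibitor, a lower number a stronger inhibitor.
Compound 2 `COc1cc(-c2ccc3ncn(-c4cc(OC)c(OC)c(OC)c4)c3c2)cc(OC)c1OC` gives only > 10000 nM, a limit of the assay.
Compound 3 `COc1ccc(-c2ccc3ncn(-c4cc(OC)c(OC)c(OC)c4)c3c2)cc1F` gives 1430 nM.
Compound 4 `COc1cc(-n2cnc3ccc(-c4cccc(Cl)c4)cc32)cc(OC)c1OC` is not yet measured.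

Among the two numbers shown, compound 3 stands highest; the nearest is compound 1, and a 2.2-fold higher number from compound 1 to compound 3 (0.35 log units; beyond the scatter). For compound 2 the assay reports the limit of > 10000 nM in this assay, at which 1 of the 3 values shown sits, rather than a number.

Compound 4 carries 3-chlorophenyl in place of 3-fluoro-4-methoxyphenyl on an aromatic carbon. Among the measured compounds shown here, no measured step matches this exchange: the only step, a 2.2-fold higher number from compound 1 to compound 3 (0.35 log units; beyond the scatter), replaces a different group, and its modest size merely sets the scale of variation seen so far. The expected step is therefore a 1.3-fold lower number from compound 3 to compound 4 (0.11 log units; within the scatter), not beyond the scatter. Compound 4 is estimated at 1100 nM, with a range from 400 nM to 3000 nM.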

Compound 4, half-maximal inhibitory concentration: 7050 nM
Estimate against measurement, compound 4: 6.4-fold (0.81 log units) below; the measured number lies above the stated range.
By their numbers in this assay, from the lowest: compound 1; then compound 3; then compound 4. At a limit, above all of these: compound 2.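

In this assay, the chlorine-bearing pendant turns out to be no neutral swap for the other non-amino pendant on the shared core: 3-chlorophenyl in place of 3-fluoro-4-methoxyphenyl gives a clear loss (a 4.9-fold higher number from compound 3 to compound 4 (0.69 log units; beyond the scatter)). The single exchange of chloro for amino is larger still (an 11-fold higher number from compound 1 to compound 4 (1.04 log units; beyond the scatter)), so the amino-bearing pendant of compound 1 keeps the lowest number of those shown. Nothing measured here accounts for either step.

Going by these compounds, what a hydroxyl or an acetamide in place of that chloro or amino group would give remains open.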